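A few compounds are considered here, and "the series" means these few. Any claim that something is new, unique, unknown or untested is made for them only; others in the source may bear on it.

Measured so far in a functional assay on HT-29 cells (Homo sapiens) for inhibition, read by MTT assay, with a stated time of 72 h; a lower number here means a stronger inhibitor, a higher number a weaker inhibitor:
compound 1, `COc1cc(Oc2cccc(Nc3ccccc3)c2)cc(OC)c1CNC1CC1`, gives 12300 nM
compound 2, `COc1cc(Oc2cccc(Nc3ccccc3)c2)cc(OC)c1CNCCNC(C)=O`, gives 3960 nM

For the measured compounds named here, compound 2 holds the lower of these two numbers; the single measured step, a 3.1-fold lower number from compound 1 to compound 2 (0.49 log units; beyond the scatter), separates it from compound 1 and lies beyond the scatter.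

Compound 3, `COc1cc(Oc2cccc(Nc3ccccc3)c2)cc(OC)c1CNCc1ccc(C)cc1`, is not yet measured. It differs from compound 2 in one place: 4-methylphenyl in place of acetamidomethyl on a saturated chain carbon bound to an amine nitrogen. Going by the values given here, the only measured step, a 3.1-fold lower number from compound 1 to compound 2 (0.49 log units; beyond the scatter), altered the same amine attachment, but it exchanged cyclopropyl for 2-acetamidoethyl, not acetamidomethyl for 4-methylphenyl, so it informs this change only loosely. Among the compounds with values here, with no closer precedent, the expected step of a 1.0-fold higher number from compound 2 to compound 3 (0.00 log units; within the scatter) is small, carrying wide uncertainty. Compound 3 is therefore estimated at 4000 nM, expected between 1000 nM and 16000 nM.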

Compound 3, half-maximal inhibitory concentration: 3880 nM
Beside the measured number, compound 3's estimate is 1.0-fold (0.01 log units) above it; measured number inside the range.
By their numbers in this assay, from the lowest: compounds 3 and 2 (each within the scatter of the next); then compound 1.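

In this assay, putting 4-methylbenzyl on the amine nitrogen in place of 2-acetamidoethyl gives a 1.0-fold lower number from compound 2 to compound 3 (0.01 log units; within the scatter), so two very different groups read alike here: one has a carbon-only aromatic ring and no hydrogen-bond donors or acceptors, while the other has no ring but has both. Both also stand apart from cyclopropyl, as a 3.2-fold lower number from compound 1 to compound 3 (0.50 log units; beyond the scatter) shows for the 4-methylbenzyl group. Nothing measured here explains this likeness. Still open, as far as these compounds go, is how a plain benzyl, or a chain ending in an amine or a carboxylic acid, would read at this nitrogen.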